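Notes toward compound 4: methyl in place of fluoro

The compounds below may be only part of what the source reports. "The series", "measured", "known", "first", "only" and "open" are said of these compounds alone.

Compound 3 `N#Cc1cc(F)cc(C(=O)Nc2ccc(F)cc2)c1` returns only a limit in an in vitro functional assay on HEK293-A cells for antagonist activity at metabotropic glutamate receptor 5 (Rattus norvegicus), read by calcium flux (on this read-out lower numbers stand for stronger inhibition and higher numbers for weaker inhibition), > 10000 nM. The same limit is given by compound 1 `N#Cc1cc(F)cc(C(=O)Nc2nccs2)c1`, which in this assay shows > 10000 nM. Compound 2 `Cc1cnc(NC(=O)c2cc(F)cc(C#N)c2)s1` gives 863 nM in this assay. Within the data shown here, the one resolved step, an at least 11-fold lower number from compound 1 to compound 2 (1.06 log units; beyond the scatter), sits against the limit of > 10000 nM in this assay, at which 2 of the 3 values shown sit, and so reads as a lower bound on the gain. Compound 4 `Cc1ccc(NC(=O)c2cc(F)cc(C#N)c2)cc1` differs from compound 3 by methyl in place of fluoro on an aromatic carbon. Among the measured compounds shown here, no measured step exchanges fluoro for methyl, and the measured methyl step falls on a different ring of the shared core, so it bears only loosely here. For compound 4 a modest gain is expected, an at least 1.6-fold lower number from compound 3 to compound 4 (0.22 log units; that floor lies within the scatter), with a real chance of another limit. The estimate for compound 4 is 6000 nM, within 1500 nM to 30000 nM.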

Compound 4, half-maximal inhibitory concentration: > 30000 nM
Compound 4: only a limit was reported; the forecaster's own chance of this, stated with the estimate: 45%; middle value at least 5.0-fold (0.69 log units) away from the limit.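

Among these compounds, compound 3 and compound 4 both return only limits in this assay, and no step between them can be read. From the compounds shown here alone, whether methyl in place of fluoro on an aromatic carbon moves the number in either direction stays open.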